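The source may report more compounds than this note shows. Statements on the series, on what has been measured and on what is new or still open speak of the compounds shown alone.

Among the compounds with values here, compound 2 `O=C(Nc1ccc(Cl)c(Cl)c1)Nc1nnc(Sc2ncnc3scc(-c4ccncc4)c23)s1` gives, in a functional assay on HepG2 cells (Homo sapiens) for antiproliferative activity, read by MTT assay, with a stated time of 48 h (a lower number here means a stronger inhibitor, a higher number a weaker inhibitor), a value of 61900 nM, and on the numbers so far it stands highest of the two measured compounds. Its nearest neighbour is compound 1 `Cc1ccc(NC(=O)Nc2nnc(Sc3ncnc4scc(-c5ccncc5)c34)s2)cc1Cl`, which in this assay gives 16000 nM. These two differ in one place, and the step is a 3.9-fold higher number from compound 1 to compound 2 (0.59 log units; beyond the scatter), so a single change at the aryl ring can move the number beyond the scatter.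

Compound 3 `O=C(Nc1cccc(F)c1)Nc1nnc(Sc2ncnc3scc(-c4ccncc4)c23)s1` has not yet been measured. Compared with compound 2 it carries 3-fluorophenyl in place of 3,4-dichlorophenyl on an amide-type nitrogen. Within the data shown here, the one measured step bears on it only loosely, because a 3.9-fold higher number from compound 1 to compound 2 (0.59 log units; beyond the scatter) concerns a different exchange on the same ring; no measured pair shows the present exchange. A modest step is therefore expected, with little certainty about its direction, and compound 3 is estimated to reach 30000 nM in this assay, within a range from 8000 nM to 120000 nM. That estimate means a step of a 2.1-fold lower number from compound 2 to compound 3 (0.31 log units; beyond the scatter) from compound 2 to compound 3, which is expected to stay close to the scatter.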

Compound 3, half-maximal inhibitory concentration: 64100 nM
Compound 3: the middle estimate sits 2.1-fold (0.33 log units) below what was measured; the measured number falls inside the stated range.
By their numbers in this assay, from the lowest: compound 1; then compounds 2 and 3 (each within the scatter of the next).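

Exchanging 3,4-dichlorophenyl for 3-fluorophenyl on the amide-type nitrogen gives a 1.0-fold higher number from compound 2 to compound 3 (0.02 log units; within the scatter) in this assay and so leaves the two compounds indistinguishable, even though the entering group has one heavy atom fewer and carries a single fluorine in place of two chlorines. Against the 3-chloro-4-methylphenyl group, the same 3-fluorophenyl group gives a 4.0-fold higher number from compound 1 to compound 3 (0.60 log units; beyond the scatter) and matches the earlier step in size, so among these three compounds only the one with 3-chloro-4-methylphenyl stands apart, with the lower number. No measurement shown here explains why these aryl groups behave this way.

The compounds shown do not separate the contribution of the methyl group from that of the chlorine in the 3-chloro-4-methylphenyl group, since no ring carrying only one of them appears among them. From the compounds shown here alone, it also remains open how this position would respond to an unsubstituted phenyl ring, or to a ring bearing a methoxy group, an amine or a carboxylic acid, and whether any such group would bring the number below that of compound 1 16000 nM.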